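Bromo-methylphenyl variant of a cyclohexylamino imidazopyrimidine series

The source may report more compounds than this note shows. Statements on the series, on what has been measured and on what is new or still open speak of the compounds shown alone.

Working notes on the cytotoxicity series. Compound 1 `Fc1ccc(COc2ccc(-c3nc4ncccn4c3NC3CCCCC3)cc2)cc1` gives 24000 nM in a toxicity assay on A549 cells (Homo sapiens) for cytotoxicity, read by luminescence and CellTiter-Glo, with a stated time of 48 h; on this read-out higher numbers stand for lower toxicity in this test and lower numbers for higher toxicity in this test. Compound 2 `Clc1ccc(-c2nc3ncccn3c2NC2CCCCC2)cc1` reaches only the upper limit of this assay, reported as > 100000 nM, so no number is known for it. The step of an at least 4.1-fold higher number from compound 1 to compound 2 (0.61 log units; beyond the scatter) is therefore only a lower bound on the true change, which follows from the limit of > 100000 nM in this assay, at which 1 of the 2 values shown sits.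

Compound 3 `Cc1cc(Br)ccc1-c1nc2ncccn2c1NC1CCCCC1` differs from compound 2 by 4-bromo-2-methylphenyl in place of 4-chlorophenyl on an aromatic carbon. Within the data shown here, no measured step covers this exchange: the only step known, from compound 1 to compound 2, concerns a different replacement on the shared core and cannot be carried over. What is known is simply where compound 2 stands, at the limit of this assay.

Among the measured compounds shown here, with no step to lean on, compound 3 is expected to stay close to where compound 2 sits, and the step of a number no higher from compound 2 to compound 3 (the limit leaves the size open) is estimated to fall within the scatter. Compound 3 is thus estimated at 100000 nM, with a range from 30000 nM to 300000 nM, and it is likely that this assay again reports only a limit rather than a number.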

Compound 3, half-maximal cytotoxic concentration: 45000 nM
The estimate for compound 3 lay 2.2-fold (0.35 log units) above the measured number; measured number inside the range.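

In this assay the exchange of 4-chlorophenyl for 4-bromo-2-methylphenyl on this aromatic carbon gives an at least 2.2-fold lower number from compound 2 to compound 3 (0.34 log units; beyond the scatter), so a change of the aryl group alone, with the cyclohexylamino group and the shared core kept, moves the read-out towards higher toxicity. The series therefore does not need the (4-fluorobenzyl)oxy group of compound 1 for a number to be read in this test, since compound 3 gives one without it. The true size of the step stays open, and the figure is only a lower bound: the limit of > 100000 nM in this assay, at which 1 of the 3 values shown sits.

Bromo and methyl enter together here, so their separate shares in the step remain unresolved, and 4-bromophenyl and 2-methylphenyl at the same carbon would be the pair to separate them. Also open, on these data alone, is how this position responds to an aryl group carrying an amine or a carboxylic acid, and whether the same exchange behaves alike when the cyclohexylamino group gives way to a shorter alkylamino chain.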